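Hydroxymethyl in place of formyl on compound 2

The source may hold more compounds than are shown below. What is called first, only, known or untested is meant among the compounds shown, and "the series" means these compounds.

In an ADME assay on T29 cells (Homo sapiens) for cytotoxicity, read by sulforhodamine B assay, with a stated time of 3 days (on this read-out higher numbers stand for weaker inhibition and lower numbers for stronger inhibition), compound 1 `O=Cc1cn(Cc2cccc(Br)c2)c2ccccc12` gives > 31600 nM and this is a limit of the assay. Compound 2 `O=Cc1cn(Cc2ccc(Br)c(Br)c2)c2ccccc12` gives > 31600 nM and this too is a limit of the assay, so compound 2 has no readable number. Going by the values given here, the series so far shows the limit of > 31600 nM in this assay, at which 2 of the 2 values shown sit, and nothing finer. Among the compounds with values here, the one measured step is a step that the two limits leave unreadable from compound 1 to compound 2 and it concerns bromo in place of hydrogen on an aromatic carbon, a different change from the one at hand. Compound 3 `OCc1cn(Cc2ccc(Br)c(Br)c2)c2ccccc12` carries hydroxymethyl in place of formyl on an aromatic carbon of the five-membered aromatic ring hydroxymethyl in place of formyl on an aromatic carbon and differs from compound 2 in nothing else. Within the data shown here, no measured step covers this exchange, so the expectation in this assay is weakly grounded: a reading at or near the limit, or a modest move towards lower numbers and stronger inhibition. The step expected is an at least 1.5-fold lower number from compound 2 to compound 3 (0.19 log units; that floor lies within the scatter) and it is only a rough estimate. For compound 3 the estimated value is 20000 nM with an expected range from 3000 nM to 50000 nM and a report of only a limit remains quite possible.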

Compound 3, half-maximal inhibitory concentration: > 31600 nM
Compound 3 ended at the assay's limit (the forecaster's own chance of this, stated with the estimate: 55%); middle value at least 1.5-fold (0.19 log units) from the limit.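

The step from compound 2 to compound 3 cannot be read in this assay, since neither compound has a number, and the series offers only one reading: the limit of > 31600 nM in this assay, at which 3 of the 3 values shown sit.

The compounds shown leave open how formyl and hydroxymethyl compare in this assay, and whether any change on the shared core gives a readable number there.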